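Compound 2 to compound 3: a smaller group enters

A few compounds are considered here, and "the series" means these few. Any claim that something is new, unique, unknown or untested is made for them only; others in the source may bear on it.

In a functional assay (aorta) with Rattus norvegicus as the target (on this read-out lower numbers stand for an effect already at smaller amounts and higher numbers for an effect only at larger amounts of compound), compound 1 `C/N=C(/NC)Nc1nc(-c2ccc(OC)cc2)c(-c2ccc(OC)cc2)s1` gives 2.4 uM, while compound 2 `COc1ccc(-c2nc(/N=C(\N)N3CCOCC3)sc2-c2ccc(OC)cc2)cc1` gives 66 uM, the higher of the two numbers. Among the measured compounds shown here, only one measured step bears on the change at hand: a 28-fold higher number from compound 1 to compound 2 (1.44 log units; beyond the scatter). That step is large and beyond the scatter, and it came with the ring-bearing group of compound 2 taking the place of an open-chain group on the same aromatic carbon.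

Compound 3 `COc1ccc(-c2nc(CN(C)C)sc2-c2ccc(OC)cc2)cc1` keeps the shared core and both 4-methoxyphenyl groups and changes that same place: a group of 4 heavy atoms (3 carbon, 1 nitrogen; no ring) in place of a group of 9 heavy atoms (5 carbon, 3 nitrogen, 1 oxygen; one six-membered non-aromatic ring with 2 hetero atoms), on an aromatic carbon. The ring-bearing group leaves and (dimethylamino)methyl enters, on an aromatic carbon of the five-membered aromatic ring with 1 nitrogen and 1 sulfur.

For the measured compounds named here, the entering group is not the one carried by compound 1, so a single step gives only a rough guide and no trend. Removal of the ring-bearing group should recover part of the large step, not all of it. The expected change is a 5.5-fold lower number from compound 2 to compound 3 (0.74 log units; beyond the scatter), towards a lower number and beyond the scatter. For compound 3 the estimated value is 12 uM, with an expected range from 2.5 uM to 60 uM.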

Compound 3, concentration for half-maximal effect: 8.4 uM
Beside the measured number, compound 3's estimate is 1.4-fold (0.15 log units) above it; the measured number falls inside the stated range.
By their numbers in this assay, from the lowest: compound 1; then compound 3; then compound 2.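

In this assay, swapping the ring-bearing group for (dimethylamino)methyl on this aromatic carbon gives a 7.9-fold lower number from compound 2 to compound 3 (0.90 log units; beyond the scatter), so a group with no ring and 0 hydrogen-bond donors can recover much of the large loss seen with the ring-bearing group, and a hydrogen-bond donor on this carbon is not needed for an effect at this level. Removing the ring does not by itself restore the number of the open-chain group in compound 1, since the comparison with that compound gives a 3.5-fold higher number from compound 1 to compound 3 (0.54 log units; beyond the scatter), which shows that the two ring-free groups also differ from each other beyond the scatter. The data at hand contain no measurement that explains either step.

On these data alone, it remains open whether the ring, the overall size of the group or some other feature of the replaced groups governs the number at this place. A primary amine such as aminomethyl, a longer chain such as 2-(dimethylamino)ethyl or a carboxylic acid on this carbon would help to separate these possibilities, and the two 4-methoxyphenyl groups have so far stayed constant.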